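The source may report more compounds than this note shows. Statements on the series, on what has been measured and on what is new or still open speak of the compounds shown alone.

Measured compounds in a functional assay on NCI-H522 cells (Homo sapiens) for inhibition, read by sulforhodamine B assay, with a stated time of 48 h; a lower number here means a stronger inhibitor of growth, a higher number a weaker inhibitor of growth:

Compound 1, `COc1cc(-c2nn(-c3cccc(NC(=O)c4cccc(C(F)(F)F)c4)c3)cc2-c2ccncc2)ccc1Cl` — 1050 nM
Compound 2, `O=C(Nc1cccc(-n2cc(-c3ccncc3)c(-c3ccc(Cl)c(O)c3)n2)c1)Nc1cc(C(F)(F)F)cc(C(F)(F)F)c1` — 724 nM
Compound 3, `O=C(Nc1cccc(-n2cc(-c3ccncc3)c(-c3ccc(Cl)c(O)c3)n2)c1)Nc1ccc(Cl)c(C(F)(F)F)c1` — 720 nM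

Compound 1 gives the highest of the three numbers, but its gap to compound 2 and to compound 3 lies within the scatter, so the three compounds cannot be ranked against one another in this assay. Compound 2 and compound 3 both carry a urea in place of the amide of compound 1 and a hydroxy group where compound 1 carries a methoxy group, so neither is a single-change neighbour of compound 1.

Compound 4, `COc1cc(-c2nn(-c3cccc(NC(=O)Nc4ccc(Cl)c(Cl)c4)c3)cc2-c2ccncc2)ccc1Cl`, has not yet been measured in this assay. It differs from compound 1 in one place: (3,4-dichlorophenyl)amino in place of 3-(trifluoromethyl)phenyl on a carbonyl carbon. This turns the amide of compound 1 into a urea, the same linker found in compound 2 and compound 3, while the rest of compound 1 is kept. Since compound 2 and compound 3 sit within the scatter of compound 1, the step from compound 1 to compound 4 is expected to be small, a 1.3-fold lower number from compound 1 to compound 4 (0.12 log units; within the scatter), and not clearly beyond the scatter in either direction. Compound 4 is therefore estimated at 800 nM, with a range from 300 nM to 2500 nM.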

Compound 4, concentration for 50% growth inhibition: 811 nM
The estimate for compound 4 lay 1.0-fold (0.01 log units) below the measured number; low and high end bracket the measured number.
By their numbers in this assay, from the lowest: compounds 3, 2, 4 and 1 (each within the scatter of the next).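

In this assay, the change from (3-(trifluoromethyl)phenyl)carbonyl to (3,4-dichlorophenyl)carbamoyl gives a direct reading at this position, with a 1.3-fold lower number from compound 1 to compound 4 (0.11 log units; within the scatter) on an otherwise unchanged core. With the methoxy group kept, the amide can therefore give way to a urea bearing a different aryl ring without a shift beyond the scatter. No measurement available here explains why the number holds across this change.

Linker and ring substituents change together in this step, so the contribution of each remains unresolved, and a urea carrying 3-(trifluoromethyl)phenyl would be needed to separate them. As far as these compounds go, it also remains open whether this position tolerates a non-aromatic group, such as a morpholine or a longer alkyl chain, in place of the aryl ring.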